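The compounds below may be only part of what the source reports. "The series", "measured", "known", "first", "only" and "open" are said of these compounds alone.

Among the compounds with values here, in a functional assay on the whole organism with Rattus norvegicus as the target (on this read-out lower numbers stand for an effect already at smaller amounts and higher numbers for an effect only at larger amounts of compound), compound 1 (`CCNc1cccc(NC(=O)C(=O)OCC)c1C#N`) gives 0.03 mg/kg and compound 2 (`CCOC(=O)C(=O)Nc1cccc([N+](=O)[O-])c1C#N`) gives 0.4 mg/kg as the higher of the two numbers so far. Compound 3 (`CCOC(=O)C(=O)Nc1cccc(C(=O)OC)c1C#N`) carries methoxycarbonyl in place of nitro on an aromatic carbon. Within the data shown here, the only measured step at this place swapped ethylamino for nitro and was large (a 13-fold higher number from compound 1 to compound 2 (1.12 log units; beyond the scatter)), but it says little about methoxycarbonyl, which has no measurement yet. In this assay a step within the scatter is therefore expected, with no firm direction. The expected step is small (a 1.3-fold lower number from compound 2 to compound 3 (0.12 log units; within the scatter)) and no more. The estimated value for compound 3 is 0.3 mg/kg (expected range 0.08 mg/kg to 1.2 mg/kg).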

Compound 3, dose for half-maximal effect: 1.2 mg/kg
Compound 3: middle estimate off by 4.0-fold (0.60 log units), on the low side; the range from low to high includes it.
By their numbers in this assay, from the lowest: compound 1; then compound 2; then compound 3.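

In this assay, methoxycarbonyl is a second group at this position that needs a larger dose than ethylamino, with a 40-fold higher number from compound 1 to compound 3 (1.60 log units; beyond the scatter) as the wider of the two gaps from compound 1. Replacing nitro with methoxycarbonyl also matters, giving a 3.0-fold higher number from compound 2 to compound 3 (0.48 log units; beyond the scatter) even though both groups count the same hydrogen-bond donors and acceptors, so those counts alone do not settle the dose. Nothing available explains this difference.

From the compounds shown here alone, it remains open whether a primary amine or a longer chain such as butylamino would stay near compound 1. A carboxylic acid at this position is also an open case.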